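Saturating the Alkyne: From Cyclohexylethynyl to Hexyl

A few compounds are considered here, and "the series" means these few. Any claim that something is new, unique, unknown or untested is made for them only; others in the source may bear on it.

Measured compounds:
- compound 1, `CCCCC#Cc1ccc(S(=O)(=O)Nc2cccc(-c3csc(NC(C)=O)n3)c2)cc1`: 73.2%
- compound 2, `CC(=O)Nc1nc(-c2cccc(NS(=O)(=O)c3ccc(C#CC4CCCCC4)cc3)c2)cs1`: 52.3%
- compound 3, `CC(=O)Nc1nc(-c2cccc(NS(=O)(=O)c3cccc(C#CCO)c3)c2)cs1`: 85.4%

In a functional assay on A-375 cells (Homo sapiens) for antiproliferative activity, read by trypan blue exclusion, with a stated time of 48 h, tested at 1 uM (on this read-out higher numbers stand for a weaker effect at the one concentration tested and lower numbers for a stronger effect), compound 2 gives the lowest number of the three measured compounds, which here means the strongest effect; compound 1 stands nearer to it and compound 3 furthest away, both beyond the scatter. The new compound 4, `CCCCCCc1ccc(S(=O)(=O)Nc2cccc(-c3csc(NC(C)=O)n3)c2)cc1`, differs from compound 2 in one place: hexyl in place of 2-cyclohexylethynyl on an aromatic carbon. Going by the values given here, only one measured step is related to this change: a number 20.9 percentage points lower from compound 1 to compound 2 (beyond the scatter), where a ring was added at the end of the triple bond. Compound 4 goes the other way, losing the ring and the triple bond and keeping a plain chain, so the number is expected to climb back toward that of compound 1 rather than to fall further. The estimate for compound 4 is therefore 70%, with a range from 55% to 85%, expected as a step of a number 17.7 percentage points higher from compound 2 to compound 4 (beyond the scatter) in this assay.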

Compound 4, a percentage reported as activity, at one concentration (the size of the read-out at that concentration, not a potency): 49.9%
Estimate against measurement, compound 4: 20.1 percentage points above; measured number outside the range, below it.
By their numbers in this assay, from the lowest: compounds 4 and 2 (each within the scatter of the next); then compound 1; then compound 3.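

In this assay, hexyl and 2-cyclohexylethynyl on this aromatic carbon cannot be told apart, with a number 2.4 percentage points lower from compound 2 to compound 4 (within the scatter), so neither the cyclohexyl ring nor the triple bond is needed to reach the number seen for compound 2. Going by these compounds alone, the straight chains do differ, with a number 23.3 percentage points lower from compound 1 to compound 4 (beyond the scatter) for hexyl in place of hex-1-yn-1-yl, so adding a ring to the end of the triple bond is not the only change here that gives a stronger effect. No other measurement bears on why these groups compare as they do.

Still open, as far as these compounds go, is whether a longer chain such as octyl, or a hexyl chain ending in an amine or a carboxylic acid, would hold this effect. Also open, from the compounds shown here alone, is how a 2-cyclohexylethyl group would compare with hexyl.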